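The compounds below may be only part of what the source reports. "The series", "measured", "known", "first", "only" and "open" are said of these compounds alone.

Measured so far in an ADME assay on cells (Hepatocyte, Rattus norvegicus, strain Wistar Han) for pharmacokinetics, read by LC-MS, with a stated time of 1 h, tested at 0.5 uM; a higher number here means faster removal of the compound, a lower number slower removal:
Compound 1 `CNC(=O)c1cc(C(=O)NC)c2c(c1)[C@H](c1ccccc1)[C@@H](CF)O2` gives 3.02 mL/min.
Compound 2 `CNC(=O)c1cc(C(=O)NC2CC2)cc2c1O[C@H](CF)[C@H]2c1ccccc1` gives 3.2 mL/min.

Of the two numbers compound 2 has the higher one, but the step of a 1.1-fold higher number from compound 1 to compound 2 (0.03 log units; within the scatter) lies within the scatter, so the two compounds are not distinguished in this assay. Compound 3 `CNC(=O)c1cc(C(=O)N[C@@H]2[C@@H]3COC[C@@H]32)cc2c1O[C@H](CF)[C@H]2c1ccccc1` is not yet measured. It differs from compound 2 by a group of 6 heavy atoms (5 carbon, 1 oxygen; one three-membered non-aromatic ring of carbon only, one five-membered non-aromatic ring with 1 hetero atom) in place of a group of 3 heavy atoms (3 carbon; one three-membered non-aromatic ring of carbon only), on an amide-type nitrogen. Among the measured compounds shown here, the only measured step at this amide-type nitrogen is the one from compound 1 to compound 2, and it stayed within the scatter; nothing measured bears on the entering group itself. A step no larger than the scatter is therefore expected, no change at the digits printed from compound 2 to compound 3 (within the scatter). Compound 3 is estimated at 3.2 mL/min, with a range of 1.6 mL/min to 6.4 mL/min.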

Compound 3, intrinsic clearance in a liver preparation (reported as CLH), per the amount of preparation that the assay uses: 1.76 mL/min
Compound 3: the middle estimate sits 1.8-fold (0.26 log units) above what was measured; the measured number falls inside the stated range.
By their numbers in this assay, from the lowest: compounds 3, 1 and 2 (each within the scatter of the next).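

In this assay the group of 6 heavy atoms, with its five-membered non-aromatic ring and hydrogen-bond acceptor, shows a 1.8-fold lower number from compound 2 to compound 3 (0.26 log units; within the scatter) and a 1.7-fold lower number from compound 1 to compound 3 (0.23 log units; within the scatter). This amide-type nitrogen has therefore now carried a group of 6 heavy atoms, not only cyclopropyl or one carbon atom, with every step staying within the scatter. Nothing at hand bears on the reason for these numbers. Still open, on these data alone, is whether a carboxylic acid or an amine carried on this nitrogen would also stay within the scatter.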